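The source may hold more compounds than are shown below. What is called first, only, known or untested is meant among the compounds shown, and "the series" means these compounds.

Measured so far:
compound 1, `CCCN(CCC)c1cc(C)nc2c(-c3ccccc3OC)c(C)nn12`, an assay on isolated protein for binding affinity to corticotropin-releasing factor receptor 1 (Homo sapiens) (a higher number here means a weaker inhibitor, a lower number a stronger inhibitor), 15 nM
compound 2, `CCCN(CCC)c1cc(C)nc2c(-c3ccc(Cl)cc3)c(CO)nn12`, 11 nM

In this assay compound 1 gives 15 nM and compound 2 gives 11 nM; the two values lie within the scatter of each other, so neither can be set apart from the other. Compound 3, `CCCN(CCC)c1cc(C)nc2c(-c3ccc(C(=O)O)cc3)c(C)nn12`, has not been measured. It differs from compound 1 by 4-carboxyphenyl in place of 2-methoxyphenyl on an aromatic carbon. Within the data shown here, no measured pair follows this change, so its effect is not known from the data. The estimate for compound 3 is 300 nM, with a range from 50 nM to 3000 nM, which means an expected step to a weaker inhibitor a 20-fold higher number from compound 1 to compound 3 (1.30 log units; beyond the scatter) beyond the scatter.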

Compound 3, inhibition constant: > 10000 nM
Compound 3 ended at the assay's limit; the forecaster's own chance of this, stated with the estimate: 10%; middle value at least 33-fold (1.52 log units) from the limit.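

Among these compounds, exchanging 2-methoxyphenyl for 4-carboxyphenyl on this aromatic carbon gives an at least 660-fold higher number from compound 1 to compound 3 (2.82 log units; beyond the scatter) in this assay, the first step that can be read at this position. The position therefore does not accept every substituted phenyl group on the core of compound 1. The value of compound 3 is a limit of the assay, not a number: the limit of > 10000 nM in this assay, at which 1 of the 3 values shown sits.

The compounds shown leave open whether this step follows from the carboxylic acid itself or from the departure of the methoxy group. On these data alone, how a methyl ester or a primary amide would behave on this phenyl ring also remains open.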